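The compounds below may be only part of what the source reports. "The series", "measured", "known", "first", "only" and "open" are said of these compounds alone.

For the measured compounds named here, in an ADME assay on BHK cells (Mesocricetus auratus) for cytotoxicity, read by MTT assay, with a stated time of 96 h (a lower number here means that less compound is tolerated, a higher number that more compound is tolerated), compound 1 (`CC[C@H]1CC[C@H](c2ccc(NC(=S)Nc3cccc(C(F)(F)F)c3)cc2)CC1`) gives 10000 nM, while compound 2 (`FC(F)(F)c1cccc(NC(=S)Nc2ccccc2)c1`) gives 41000 nM, which makes compound 2 the higher of the two numbers so far. Compound 3 (`CC(=O)NC(=S)Nc1cccc(C(F)(F)F)c1`) has not yet been measured. It differs from compound 2 by acetyl in place of phenyl on an amide-type nitrogen. Going by the values given here, only one measured step is available as a guide, hydrogen in place of 4-ethylcyclohexyl on an aromatic carbon (a 4.1-fold higher number from compound 1 to compound 2 (0.61 log units; beyond the scatter)). That step was modest and lies at another place in the structure, so it bears on the new change only loosely. Among the compounds with values here, no measured step tests a change on the amide-type nitrogen, and a single step cannot establish a trend. Even so, it is one case where losing a larger group went with a higher number, and phenyl is here replaced by acetyl, so a modest rise in this assay is expected, with wide uncertainty. The expected step is similar in size to the measured one (a 2.1-fold higher number from compound 2 to compound 3 (0.32 log units; beyond the scatter)). For compound 3 the estimated value is 85000 nM, with an expected range from 30000 nM to 200000 nM.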

Compound 3, half-maximal cytotoxic concentration: > 100000 nM
Compound 3 gave a limit, no number; the forecaster's own chance of this, stated with the estimate: 30%; at least 1.1-fold (0.07 log units) between middle value and limit.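

In this assay, for the compounds shown here, the amide-type nitrogen is tested for the first time, and this position proves responsive to the change of group: the replacement of phenyl by acetyl gives an at least 2.4-fold higher number from compound 2 to compound 3 (0.38 log units; beyond the scatter). The value for compound 3 is a limit of the assay and not a number, so this step fixes only a minimum size, and the full size stays unknown: the limit of > 100000 nM in this assay, at which 1 of the 3 values shown sits. Together with the earlier step at another place in the structure, a 4.1-fold higher number from compound 1 to compound 2 (0.61 log units; beyond the scatter), this gives two cases in which a group with fewer heavy atoms enters and the number rises, with no shown compound going against them, although two steps at different places do not establish a trend.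

The compounds shown do not separate the loss of the six-membered aromatic ring from the entry of the acetyl carbonyl, and how a plain propyl chain or a carboxylic acid on this nitrogen would read in this assay remains open. On these data alone, how far compound 3 lies past its limit also remains open.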